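Enlarging the hydroxylated ring on the aminonitrile core

The source may report more compounds than this note shows. Statements on the series, on what has been measured and on what is new or still open speak of the compounds shown alone.

Of the compounds shown here, three sharing the same core have been tested in an assay on isolated protein for inhibition of protein kinase C delta type (Homo sapiens), read by TR-FRET, with a stated time of 2 h; on this read-out lower numbers stand for stronger inhibition and higher numbers for weaker inhibition. Compound 1 `N#Cc1cnc(NCc2cnccc2C(F)(F)F)cc1N[C@H]1C[C@H](O)C1` gives only a limit in this assay, > 10000 nM, so its true potency is not known beyond that; it sits at the limit of > 10000 nM in this assay, at which 1 of the 3 values shown sits. Compound 2 `N#Cc1cnc(NCc2ccccc2C(F)(F)F)cc1N[C@H]1C[C@@H](C(N)=O)C1` gives 4200 nM in this assay. Compound 3 `N#Cc1cnc(NCc2cncnc2C(F)(F)F)cc1N[C@H]1CC[C@@H](O)CC1` gives 450 nM in this assay and so shows the strongest binding among the three measured.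

Compound 4 `CC1(C)C[C@@H](Nc2cc(NCc3cnccc3C(F)(F)F)ncc2C#N)CC[C@H]1O` is not yet measured. It differs from compound 1 in one place: 4-hydroxy-3,3-dimethylcyclohexyl in place of 3-hydroxycyclobutyl on a nitrogen on an aromatic ring. Compound 3, which also carries a hydroxylated six-membered ring on that nitrogen, reaches 450 nM. Compound 1, with the smaller four-membered ring, gives only a limit in this assay. On that basis the step from compound 1 to compound 4 is expected to be a large gain in this assay, well beyond the usual scatter, of about an at least 6.6-fold lower number from compound 1 to compound 4 (0.82 log units; beyond the scatter). Compound 4 is therefore expected to give roughly 1500 nM in this assay, most likely between 300 nM and 8000 nM.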

Compound 4, half-maximal inhibitory concentration: 2400 nM
Compound 4: middle estimate off by 1.6-fold (0.20 log units), on the low side, within the range that was stated.
By their numbers in this assay, from the lowest: compound 3; then compounds 4 and 2 (each within the scatter of the next). At a limit, above all of these: compound 1.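

In this assay, this position on the shared core now has a measured number and not only a limit, with the hydroxyl group kept and the ring around it changed: the swap gives an at least 4.1-fold lower number from compound 1 to compound 4 (0.61 log units; beyond the scatter). That step is a lower bound on the true size of the change, since compound 1 stands at a limit of the assay: the limit of > 10000 nM in this assay, at which 1 of the 4 values shown sits. The step also shows that this position tolerates a bulkier group than 3-hydroxycyclobutyl, as the 4-hydroxy-3,3-dimethylcyclohexyl group brings a larger ring and two extra methyl groups and still gives a lower number.

Among the compounds shown here, the single step cannot tell whether the larger ring or the two methyl groups account for the gain, and a plain 4-hydroxycyclohexyl group on the core of compound 1 would separate the two. As far as these compounds go, whether an amine could take the place of the hydroxyl group on this ring also remains open.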